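The compounds below may be only part of what the source reports. "The series", "measured", "known", "first", "only" and "open" are said of these compounds alone.

Measured so far:
compound 1 `N#Cc1ccc(O[C@H]2CN(S(=O)(=O)c3ccc(Cl)cn3)C[C@@]2(O)CO)cc1F`: 3.4
compound 2 `N#Cc1ccc(O[C@H]2CN(S(=O)(=O)c3ccc(Cl)cc3)C[C@@]2(O)CO)cc1F`: 4.1

In a physicochemical assay for lipophilicity, at pH 7.4 (on this read-out higher numbers stand for higher lipophilicity and lower numbers for lower lipophilicity), compound 1 stands at 3.4, the lower of the two numbers. Compound 3 `N#Cc1ccc(O[C@H]2CN(S(=O)(=O)c3ccc(Cl)cn3)C[C@]2(O)CO)cc1F` shares its atoms and bonds with compound 1: the two compounds have the same atoms and bonds and differ only in configuration as drawn: 1 of 2 stereo elements differ; a stereocentre at a saturated ring carbon is drawn R in compound 1 and S in compound 3. For the measured compounds named here, the only measured step, a number 0.70 log units higher from compound 1 to compound 2 (beyond the scatter), puts 4-chlorophenyl in place of 5-chloropyridin-2-yl on a sulfonyl sulfur. Going by the values given here, it leaves configuration unchanged and so gives no direct guide to size here, and no measured pair differs in configuration alone. With nothing entering or leaving, no step beyond the scatter is expected in this assay, and no direction can be assigned. The expected step is no change at the digits printed from compound 1 to compound 3 (within the scatter). For compound 3 the estimated value is 3.4, with an expected range from 3 to 3.8.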

Compound 3, distribution coefficient: 3.5
Compound 3: the middle estimate sits 0.10 log units below what was measured; the range from low to high includes it.
By their numbers in this assay, from the lowest: compounds 1 and 3 (each within the scatter of the next); then compound 2.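

In this assay, for the compounds shown here, changing the saturated ring carbon from R in compound 1 to S in compound 3 gives a number 0.10 log units higher from compound 1 to compound 3 (within the scatter), the only reading of configuration alone at this position. The reading can be tied to that stereocentre and to nothing else: the fact that compounds 1 and 3 differ only in the configuration as drawn. The one step beyond the scatter remains the exchange on the sulfonyl sulfur, a number 0.70 log units higher from compound 1 to compound 2 (beyond the scatter), so among the compounds shown, this configurational change does not move the number beyond the scatter.

The compounds shown leave open whether this stereocentre stays equally silent with 4-chlorophenyl on the sulfonyl sulfur, or with an amine or a carboxylic acid carried on the shared core. They also leave open whether configuration at this carbon matters in any read-out other than this assay.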